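This account rests on a few compounds, and the source may have more. Where it says the series, first, only, none or still open, it means among the compounds named here.

Measured so far in a functional assay on A549 cells (Homo sapiens) for inhibition, read by MTT assay, with a stated time of 24 h; a higher number here means a weaker inhibitor, a lower number a stronger inhibitor:
- compound 1, `CC1(C)[C@H]2CC[C@]1(C)N(Cc1cn(-c3ccccc3)nn1)C(=O)C2`: 70 nM
- compound 2, `CC1(C)[C@H]2CC[C@]1(C)N(Cc1cn(-c3cccc(O)c3)nn1)C(=O)C2`: 180 nM
- compound 3, `COc1cccc(-n2cc(CN3C(=O)C[C@@H]4CC[C@@]3(C)C4(C)C)nn2)c1`: 240 nM

Compound 3 gives the highest of the three numbers. Its gap to compound 2 is within the scatter, so the two cannot be ordered; the gap to compound 1 is beyond the scatter, and compound 1 is the strongest inhibitor of the set. The two steps from compound 1, a 2.6-fold higher number from compound 1 to compound 2 (0.41 log units; beyond the scatter) and a 3.4-fold higher number from compound 1 to compound 3 (0.54 log units; beyond the scatter), both show that a hydroxy or methoxy group on the phenyl ring weakens inhibition by a modest amount, while a 1.3-fold higher number from compound 2 to compound 3 (0.12 log units; within the scatter) shows no difference between the two substituents.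

Compound 4, `CC1(C)[C@H]2CC[C@]1(C)N(Cc1cn(-c3ccccc3F)nn1)C(=O)C2`, differs from compound 3 as follows: 2-fluorophenyl in place of 3-methoxyphenyl on an aromatic nitrogen. The step from compound 1 to compound 3 bears on this change in reverse: removing the methoxy should recover most of the loss seen in a 3.4-fold higher number from compound 1 to compound 3 (0.54 log units; beyond the scatter). For the measured compounds named here, no measured step tells what a fluorine on the phenyl ring does, so the estimate rests on the unsubstituted compound 1 and is widened accordingly. The expected step is a 2.4-fold lower number from compound 3 to compound 4 (0.38 log units; beyond the scatter), toward stronger inhibition. Compound 4 is expected at 100 nM, with a range from 45 nM to 250 nM.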

Compound 4, half-maximal inhibitory concentration: 240 nM
Compound 4: the middle estimate sits 2.4-fold (0.38 log units) below what was measured; the measured number falls inside the stated range.
By their numbers in this assay, from the lowest: compound 1; then compounds 2, 3 and 4 (each within the scatter of the next).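

In this assay, a fluorine on the phenyl ring also weakens inhibition relative to the unsubstituted phenyl of compound 1, with a 3.4-fold higher number from compound 1 to compound 4 (0.54 log units; beyond the scatter), so the loss is not confined to the hydroxy and methoxy groups. The exchanges among substituted rings give no change at the digits printed from compound 3 to compound 4 (within the scatter) and a 1.3-fold higher number from compound 2 to compound 4 (0.12 log units; within the scatter), so 2-fluorophenyl cannot be told apart from 3-methoxyphenyl or 3-hydroxyphenyl here, and in all three compounds a substituent goes with the weaker result against compound 1. Nothing available explains these numbers.

Fluorine and the oxygen groups differ in both identity and ring place across these compounds, so the two effects remain unseparated. As far as these compounds go, how an amine or a carboxylic acid on the phenyl ring would behave also remains open.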